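Swapping the five-membered ring for a carboxypyridine

A few compounds are considered here, and "the series" means these few. Any claim that something is new, unique, unknown or untested is made for them only; others in the source may bear on it.

Compound 1 `CCC(C)(C)Cc1c[nH]c(CCc2ccc(-n3ncnn3)cc2)n1`: 89 nM
Compound 2 `CCC(C)(C)Cc1c[nH]c(CCc2ccc(-n3ccnn3)cc2)n1`: 93 nM
Compound 3 `CCC(C)(C)Cc1c[nH]c(CCc2ccc(-c3ccns3)cc2)n1`: 102 nM

In a functional assay on HEK293 cells for agonist activity at Bombesin receptor subtype-3 (Homo sapiens), read by luminescence and calcium flux, with a stated time of 10 min (a lower number here means that less compound is needed, a higher number that more compound is needed for the effect), compound 3 gives the highest of the three numbers, yet it sits within the scatter of both neighbours: a 1.1-fold higher number from compound 1 to compound 3 (0.06 log units; within the scatter) and a 1.1-fold higher number from compound 2 to compound 3 (0.04 log units; within the scatter). So far, exchanging one small aromatic ring for another at this position has left the read-out essentially unchanged.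

Compound 4 `CCC(C)(C)Cc1c[nH]c(CCc2ccc(-c3cccnc3C(=O)O)cc2)n1` takes a larger step: 2-carboxypyridin-3-yl in place of 1,2-thiazol-5-yl on an aromatic carbon. For the measured compounds named here, no measured pair introduces a carboxylic acid or a six-membered ring at this place, so the earlier steps bear on it only loosely; they suggest the position tolerates variation, but not a change of this kind. A step beyond the scatter in this assay is therefore possible in either direction, with a weak lean toward a higher number given the added group.

For compound 4 the expected step is a 1.8-fold higher number from compound 3 to compound 4 (0.25 log units; within the scatter). Compound 4 is estimated at 180 nM, with a range from 50 nM to 700 nM.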

Compound 4, half-maximal effective concentration: 95 nM
Estimate against measurement, compound 4: 1.9-fold (0.28 log units) above; measured number inside the range.
By their numbers in this assay, from the lowest: compounds 1, 2, 4 and 3 (each within the scatter of the next).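

In this assay, the 2-carboxypyridin-3-yl group brings a six-membered ring, a carboxylic acid and a hydrogen-bond donor that the 1,2-thiazol-5-yl group lacks, yet the steps stay small: a 1.1-fold lower number from compound 3 to compound 4 (0.03 log units; within the scatter), a 1.0-fold higher number from compound 2 to compound 4 (0.01 log units; within the scatter) and a 1.1-fold higher number from compound 1 to compound 4 (0.03 log units; within the scatter). The earlier compounds shown here showed only that one small five-membered aromatic ring can replace another here, whereas compound 4 extends this to a larger six-membered ring carrying a carboxylic acid, with no step beyond the scatter. No measurement at hand explains why the number stays so flat.

Going by these compounds, whether the carboxylic acid itself plays any part stays open, since a methyl ester or a plain pyridine ring would be needed to test it. On these data alone, it is also open whether an amine or a longer chain at this place would leave the number just as flat.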